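This account rests on a few compounds, and the source may have more. Where it says the series, first, only, none or still open, it means among the compounds named here.

Compounds measured so far:
compound 1, `COC(=O)c1cccc(Nc2ncnc3ccc(NC(=O)Nc4ccc(CN5CCN(C)CC5)cc4)cc23)c1`: > 10000 nM
compound 2, `O=C(Nc1ccc(CN2CCCCC2)cc1)Nc1ccc2ncnc(Nc3cccc(C(F)(F)F)c3)c2c1`: 1050 nM

In a functional assay on A549 cells (Homo sapiens) for antiproliferative activity, read by MTT assay, with a stated time of 72 h (a higher number here means a weaker inhibitor, a lower number a stronger inhibitor), compound 1 gives only a limit, > 10000 nM (the limit of > 10000 nM in this assay, at which 1 of the 2 values shown sits). Among the measured compounds shown here, compound 2 is the single compound with a numbered value in this assay, at 1050 nM, and so stands as the only anchor for the series. Compound 3, `CN(C)Cc1ccc(NC(=O)Nc2ccc3ncnc(Nc4cccc(C(F)(F)F)c4)c3c2)cc1`, remains to be measured. It differs from compound 2 by dimethylamino in place of piperidin-1-yl on a saturated chain carbon bound to an aromatic carbon. No step between two measured compounds is shown, so nothing here fixes the size of this change. A step of a 1.2-fold higher number from compound 2 to compound 3 (0.09 log units; within the scatter) is expected, within the scatter of this assay. Compound 3 is estimated at 1300 nM, between 500 nM and 3500 nM.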

Compound 3, half-maximal inhibitory concentration: 1120 nM
Beside the measured number, compound 3's estimate is 1.2-fold (0.06 log units) above it; low and high end bracket the measured number.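

In this assay, dimethylamino in place of piperidin-1-yl on a saturated chain carbon bound to an aromatic carbon gives a 1.1-fold higher number from compound 2 to compound 3 (0.03 log units; within the scatter). At this place, the six-membered ring is therefore not required for the activity seen with compound 2. Nothing shown gives a cause for this result. Going by these compounds, it remains open whether morpholin-4-yl or diethylamino at this place would also stay within the scatter. The limit of compound 1, > 10000 nM, cannot be assigned to a single change, since compound 1 differs from the others in more than one place.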